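A few compounds are considered here, and "the series" means these few. Any claim that something is new, unique, unknown or untested is made for them only; others in the source may bear on it.

Of the compounds shown here, three have so far been tested in a functional assay on the whole organism (strain Sprague-Dawley) with Rattus norvegicus as the target; a higher number here means that more compound is needed for the effect, a lower number that less compound is needed. Compound 1 `CCCC(CCC)C(=O)NC(N)=O` gives 77 mg/kg in this assay, compound 2 `CC(C)C(C(=O)NC(N)=O)C(C)C` gives 16 mg/kg, and compound 3 `CCC[C@H](C(N)=O)C(C)C` gives 38 mg/kg. Compound 3 therefore stands second highest of the three: its number lies below that of compound 1 and above that of compound 2, and both gaps are beyond the usual scatter. Compound 4 `CCC[C@H](C(=O)NC(N)=O)C(C)C` is compound 3 with a single change, (carbamoyl in place of hydrogen on an amide-type nitrogen). Compound 1 and compound 2 both already carry this carbamoyl on the amide-type nitrogen. Like compound 3, compound 2 is branched on both sides, and compound 2 gives the lowest number of the set at 16 mg/kg. A modest step towards a lower number is therefore expected in this assay, a 1.5-fold lower number from compound 3 to compound 4 (0.18 log units; within the scatter). Compound 4 is expected to give 25 mg/kg, within a range from 10 mg/kg to 60 mg/kg.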

Compound 4, dose for half-maximal effect: 37 mg/kg
For compound 4 the middle estimate is 1.5-fold (0.17 log units) below the measured one; the measured number falls inside the stated range.
By their numbers in this assay, from the lowest: compound 2; then compounds 4 and 3 (each within the scatter of the next); then compound 1.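

In this assay the step is a 1.0-fold lower number from compound 3 to compound 4 (0.01 log units; within the scatter), so the amide hydrogen and carbamoyl on this nitrogen cannot be told apart on this side chain. Among these compounds, this pair gives the first direct reading of the amino to ureido difference, which the earlier compounds could not give on their own. No measurement at hand accounts for this result. On these data alone, compound 1 and compound 2 have no partner lacking carbamoyl, so whether the result holds for their side chains remains open. Also open, as far as these compounds go, is how a methyl or acetyl group on this nitrogen would compare.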